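The compounds below may be only part of what the source reports. "The series", "measured", "known", "first", "only" and "open" are said of these compounds alone.

Among the measured compounds shown here, in a functional assay on MOLT-4 cells (Homo sapiens) for antiproliferative activity, read by MTT assay, with a stated time of 3 days (a higher number here means a weaker inhibitor, a lower number a stronger inhibitor), compound 1 `CCCCC#Cc1cn(C/C=C\CN2C(=O)c3ccccc3C2=O)c(=O)[nH]c1=O` gives 41000 nM, the only plain number among the three compounds measured. Compound 2 `CCCCCCCCC#Cc1cn(C/C=C/CN2C(=O)c3ccccc3C2=O)c(=O)[nH]c1=O` reaches only the limit > 250000 nM in this assay. Compound 3 `CCCCCC#Cc1cn(C/C=C/CN2C(=O)c3ccccc3C2=O)c(=O)[nH]c1=O` likewise reaches only the limit > 500000 nM. For the measured compounds named here, the one step between measured compounds, a step that the two limits leave unreadable from compound 2 to compound 3, cannot be read in size because compound 2 sits at the limit of > 250000 nM in this assay, at which 1 of the 3 values shown sits, and compound 3 at the limit of > 500000 nM in this assay, at which 1 of the 3 values shown sits. Compound 1 is therefore the only firm point of reference in this assay.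

Compound 4 `Cc1ccc(C#Cc2cn(C/C=C\CN3C(=O)c4ccccc4C3=O)c(=O)[nH]c2=O)cc1` differs from compound 1 by 4-methylphenyl in place of butyl on a triple-bonded carbon. Going by the values given here, no measured step touches this kind of change: the only step on record exchanges one saturated chain for another, and its size stays hidden behind the two limits. There is thus no ground for expecting a shift beyond the scatter in either direction. The estimate for compound 4 in this assay is 35000 nM, between 6000 nM and 200000 nM. This corresponds to an expected step of a 1.2-fold lower number from compound 1 to compound 4 (0.07 log units; within the scatter).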

Compound 4, half-maximal inhibitory concentration: 266000 nM
Compound 4: middle estimate off by 7.6-fold (0.88 log units), on the low side; measured number outside the range, above it.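

At the triple-bonded carbon, the group matters in this assay: 4-methylphenyl in place of butyl gives a 6.5-fold higher number from compound 1 to compound 4 (0.81 log units; beyond the scatter), so this aromatic ring weakens the compound rather than being tolerated unchanged. Among the compounds shown here, this is the only step at this position whose size can be read, and it gives the core of compound 1 a second plain number to stand against. The data shown offer no explanation for this loss.

For the compounds shown here, only one aromatic group appears here, so it remains open whether the loss follows from the ring itself or from its methyl, and a plain phenyl, or a phenyl carrying an amine or a carboxylic acid, could separate these readings. On these data alone, it is also open how a longer chain in place of butyl would read on the core of compound 1.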